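This account rests on a few compounds, and the source may have more. Where it says the series, first, only, none or still open, it means among the compounds named here.

Measured so far:
compound 1 `COc1ccc(Br)cc1NC(=O)CN1CCN(S(=O)(=O)N2CCC(C)CC2)CC1` — 1400 nM
compound 2 `CC1CCN(S(=O)(=O)N2CCN(CC(=O)Nc3cc(Cl)ccc3OC(C)C)CC2)CC1` — 5100 nM
compound 3 `COc1ccc(Cl)cc1NC(=O)N1CCCN(S(=O)(=O)N2CCC(C)CC2)CC1` — 6200 nM

All three numbers come from an assay on HEK293 cells for inhibition of potassium channel subfamily T member 1 (Homo sapiens), read by thallium flux; a higher number here means a weaker inhibitor, a lower number a stronger inhibitor. Compound 2 stands second highest of the three. Its nearest neighbour is compound 3, with 6200 nM, and the gap between them lies within the scatter, so no order can be read between the two. Compound 1, with 1400 nM, gives a clearly lower number than compound 2, a gap beyond the scatter; compound 1 differs from compound 2 in more than one place, so that gap is not tied to any single change.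

Compound 4 `Cc1ccc(Cl)cc1NC(=O)CN1CCN(S(=O)(=O)N2CCC(C)CC2)CC1` is not yet measured. It differs from compound 2 by one change: methyl in place of isopropoxy on an aromatic carbon. Among the measured compounds shown here, no measured pair in this set isolates this change, so its size is not known from the numbers. The only pointer is that, where compound 2 carries a larger group on its ring, compound 1 carries a smaller one and gives the lower number 1400 nM, but that comparison is confounded by a second difference.

The expectation for compound 4 is therefore a modest step toward a lower number, a 2.0-fold lower number from compound 2 to compound 4 (0.31 log units; beyond the scatter), though a step of no size beyond the scatter is about as likely. Compound 4 is estimated at 2500 nM, in the range 800 nM to 8000 nM.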

Compound 4, half-maximal inhibitory concentration: > 10000 nM
Compound 4: no number, only a limit; the forecaster's own chance of this, stated with the estimate: 5%; middle value at least 4.0-fold (0.60 log units) from the limit.
By their numbers in this assay, from the lowest: compound 1; then compounds 2 and 3 (each within the scatter of the next). At a limit, above all of these: compound 4.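

Compound 4 reads in this assay as a limit of the assay and not as a number: the limit of > 10000 nM in this assay, at which 1 of the 4 values shown sits. On this aromatic carbon, ortho to a large group and para to a chloro group, methyl in place of isopropoxy gives an at least 1.9-fold higher number from compound 2 to compound 4 (0.29 log units; that floor lies within the scatter), so the smaller group brings no drop in the number here, although the size of any rise remains unfixed. Replacing the whole aryl group, 5-chloro-2-methylphenyl in place of 5-bromo-2-methoxyphenyl, gives an at least 7.1-fold higher number from compound 1 to compound 4 (0.85 log units; beyond the scatter), the first direct sign that the aryl group on the amide nitrogen can shift the number beyond the scatter while the rest of the structure stays the same.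

Still open, as far as these compounds go, is whether methoxy or bromo accounts for that gap, since the two change together in this step, and how far the true value of compound 4 lies past its limit. Also open, from the compounds shown here alone, is how a hydroxyl, an amine or a longer ether such as ethoxy would read on this same aromatic carbon, with the chloro group kept in place.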